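The source may hold more compounds than are shown below. What is called first, only, known or untested is meant among the compounds shown, and "the series" means these compounds.

Three compounds share a core in which the ring nitrogen carries a varying substituent. Compound 1 `COc1ccc(C)cc1N1C(=O)CSC1c1cccc(C(=O)NCCCCc2ccccc2)c1` gives 42% in a functional assay on HOS cells (Homo sapiens) for inhibition, read by CCK-8 assay, with a stated time of 72 h, tested at 1 uM; a higher number here means more inhibition at the concentration tested (going by the name of the read-out), a lower number less inhibition. Compound 2 `Cc1cccc(N2C(=O)CSC2c2cccc(C(=O)NCCCCc3ccccc3)c2)c1` reaches 84% in the same assay, and the change of a number 42 percentage points higher from compound 1 to compound 2 (beyond the scatter) marks that step. Compound 3 `CCN1C(=O)CSC1c1cccc(C(=O)NCCCCc2ccccc2)c1` gives 6%, the lowest of the three numbers; compound 1 stands nearest to it and compound 2 furthest.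

Compound 4 `COc1cc(F)ccc1N1C(=O)CSC1c1cccc(C(=O)NCCCCc2ccccc2)c1` follows from compound 3 by the change (4-fluoro-2-methoxyphenyl in place of ethyl on an amide-type nitrogen in a ring). Among the compounds with values here, two measured steps bear on this move in the opposite direction: the change of a number 36 percentage points lower from compound 1 to compound 3 (beyond the scatter) and the change of a number 78 percentage points lower from compound 2 to compound 3 (beyond the scatter). Both show that replacing an aryl group on the ring nitrogen by ethyl lowers inhibition strongly, so restoring an aryl group is expected to raise it again. Because compound 1, which also carries a methoxy group on that aryl ring, gives 42%, the rise for compound 4 is estimated as a number 42 percentage points higher from compound 3 to compound 4 (beyond the scatter). Compound 4 is therefore expected to give about 48%, within a range from 20% to 78%.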

Compound 4, a percentage reported as inhibition, at one concentration (the size of the read-out at that concentration, not a potency): 81%
Compound 4: the middle estimate sits 33 percentage points below what was measured; measured number outside the range, above it.
By their numbers in this assay, from the lowest: compound 3; then compound 1; then compounds 4 and 2 (each within the scatter of the next).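

In this assay the step of a number 75 percentage points higher from compound 3 to compound 4 (beyond the scatter) shows that a fluorinated aryl group on the amide-type nitrogen in a ring also gives a large change from ethyl, and the methoxy group of 4-fluoro-2-methoxyphenyl does not keep the number at the level of compound 1, as the step of a number 39 percentage points higher from compound 1 to compound 4 (beyond the scatter) shows. With the step of a number 3 percentage points lower from compound 2 to compound 4 (within the scatter) inside the scatter, 4-fluoro-2-methoxyphenyl and 3-methylphenyl cannot be told apart at this position. Nothing available here explains these steps.

The compounds shown leave open whether the fluorine or the missing methyl carries the difference between compound 1 and compound 4, since the two groups differ in both. They also leave open how that aryl ring would read with an amine or a carboxylic acid on it.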